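The source may report more compounds than this note shows. Statements on the series, on what has been measured and on what is new or still open speak of the compounds shown alone.

Working notes on the series. In a functional assay on HT-29 cells (Homo sapiens) for inhibition, read by MTT assay (a higher number here means a weaker inhibitor, a lower number a stronger inhibitor), compound 1 (`N#Cc1c(N)sc(C(=O)Nc2ccccc2)c1-c1ccccc1`) gives 8390 nM and compound 2 (`CCOC(=O)c1c(NC(=O)CC#N)sc(C(=O)Nc2ccccc2)c1-c1ccccc1`) gives 630 nM as the lower of the two numbers, with the gap between them beyond the scatter. Compound 2 therefore stands as the stronger inhibitor of this pair. The next compound to read is compound 3 (`N#CCC(=O)Nc1sc(C(=O)Nc2ccccc2)c(-c2ccccc2)c1C#N`), which carries cyano in place of ethoxycarbonyl on an aromatic carbon and otherwise matches compound 2. Within the data shown here, no measured step isolates this swap, so the expectation is loose. A modest move toward a higher number in this assay is expected, perhaps none beyond the scatter, and the estimated size is (a 1.6-fold higher number from compound 2 to compound 3 (0.20 log units; within the scatter)). For compound 3 the estimated value is 1000 nM (expected range 220 nM to 4500 nM).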

Compound 3, half-maximal inhibitory concentration: 6590 nM
Beside the measured number, compound 3's estimate is 6.6-fold (0.82 log units) below it; measured number outside the range, above it.
By their numbers in this assay, from the lowest: compound 2; then compounds 3 and 1 (each within the scatter of the next).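

In this assay, among these compounds, replacing ethoxycarbonyl on this aromatic carbon with cyano gives a 10-fold higher number from compound 2 to compound 3 (1.02 log units; beyond the scatter) as the first measured step at this position, and it is a large one. With cyano in place, adding (cyanomethyl)carbonyl to the ring nitrogen gives a 1.3-fold lower number from compound 1 to compound 3 (0.10 log units; within the scatter) and stays within the scatter, so this group shows no readable effect on the cyano-bearing compounds. Nothing on hand accounts for the size of the cyano step.

Still open, from the compounds shown here alone, is whether a carboxylic acid, a primary carboxamide or a longer ester chain on this carbon would stay near compound 2 630 nM or move toward compound 3 6590 nM in this assay as the swap to cyano did. Also open, going by these compounds, is what (cyanomethyl)carbonyl contributes on the nitrogen when ethoxycarbonyl stays on the ring.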